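The source may report more compounds than this note shows. Statements on the series, on what has been measured and on what is new or still open speak of the compounds shown alone.

Compound 3 `O=C(O)c1ccccc1-c1ccc(CCc2ncc(CCc3ccccc3)[nH]2)cc1` is the starting point of this step. In an in vitro functional assay on cells for agonist activity at Bombesin receptor subtype-3 (Homo sapiens), read by luminescence and calcium flux (a higher number here means that more compound is needed for the effect, a lower number that less compound is needed), compound 3 gives 1320 nM, the highest of the three numbers measured. Its neighbours are compound 2 `O=C(O)c1ccccc1-c1ccc(CCc2ncc(Cc3cccc(Cl)c3)[nH]2)cc1`, which in this assay gives 825 nM, and compound 1 `O=C(O)c1ccccc1-c1ccc(CCc2ncc(CCC3CCCCC3)[nH]2)cc1`, which in this assay gives 642 nM. The steps up to compound 3 are a 1.6-fold higher number from compound 2 to compound 3 (0.20 log units; within the scatter) and a 2.1-fold higher number from compound 1 to compound 3 (0.31 log units; beyond the scatter); between the other two compounds the step is a 1.3-fold higher number from compound 1 to compound 2 (0.11 log units; within the scatter).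

Compound 4 `O=C(O)c1ccccc1-c1ccc(CCc2ncc(Cc3cccc(F)c3F)[nH]2)cc1` has not yet been measured. It differs from compound 3 in one place: 2,3-difluorophenyl in place of benzyl on a saturated chain carbon bound to an aromatic carbon. The step that bears most directly on it is a 1.6-fold higher number from compound 2 to compound 3 (0.20 log units; within the scatter), where a halogen-bearing phenyl on that same chain carbon went with a lower number than the benzyl of compound 3, though within the scatter. Nothing measured speaks to fluorine or to two halogens on the ring. The expectation for compound 4 in this assay is therefore a small move toward a lower number, a 1.5-fold lower number from compound 3 to compound 4 (0.17 log units; within the scatter), a change that need not rise beyond the scatter. Compound 4 is estimated at 900 nM, with a range from 350 nM to 2500 nM.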

Compound 4, half-maximal effective concentration: 87 nM
For compound 4 the middle estimate is 10-fold (1.01 log units) above the measured one; measured number outside the range, below it.
By their numbers in this assay, from the lowest: compound 4; then compounds 1, 2 and 3 (each within the scatter of the next, the first and the last beyond it).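

In this assay, going by these compounds alone, the saturated chain carbon bound to an aromatic carbon proves far more responsive than the earlier compounds suggested: placing 2,3-difluorophenyl there gives a 15-fold lower number from compound 3 to compound 4 (1.18 log units; beyond the scatter) and so exceeds the largest earlier difference, a 2.1-fold higher number from compound 1 to compound 3 (0.31 log units; beyond the scatter) in size. Compound 4 also stands apart from the other halogen-bearing phenyl, with a 9.5-fold lower number from compound 2 to compound 4 (0.98 log units; beyond the scatter) for the change from 3-chlorophenyl, and from the saturated group, with a 7.4-fold lower number from compound 1 to compound 4 (0.87 log units; beyond the scatter) for the change from cyclohexylmethyl, so a single chlorine on the ring does not reach this number and compound 4 has the lowest number of the four. No available evidence bears on why this pair of fluorines goes with so large a step.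

The compounds shown leave open whether both fluorines are needed or a single fluorine would do, and whether methoxy or trifluoromethyl on the ring would give a number as low. They also do not tell whether 2,3-difluorophenethyl, with its longer chain, would keep the low number of compound 4.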